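Three Measured Compounds and One Expected Value

A few compounds are considered here, and "the series" means these few. Any claim that something is new, unique, unknown or untested is made for them only; others in the source may bear on it.

Compound 1 `O=C(CN1CCN(c2ccccc2)CC1)Nc1nc2ccccc2[nH]1` gives 11.5% in a functional assay, read by spectrophotometry, with a stated time of 30 min, tested at 25 ug/mL; a lower number here means a weaker effect, a higher number a stronger effect of the compound at the concentration tested.
Compound 2 `O=C(CN1CCN(c2ncccn2)CC1)Nc1nc2ccccc2[nH]1` gives 20.4% in this assay.
Compound 3 `O=C(CN1CCN(c2ccc([N+](=O)[O-])cc2)CC1)Nc1nc2ccccc2[nH]1` gives 33.9% in this assay.

Compound 3 stands highest of the three: the step of a number 13.5 percentage points higher from compound 2 to compound 3 (beyond the scatter) and the step of a number 22.4 percentage points higher from compound 1 to compound 3 (beyond the scatter) are both beyond the scatter, so its lead over compound 1 and compound 2 is real, while the step of a number 8.9 percentage points higher from compound 1 to compound 2 (within the scatter) is within the scatter, so compound 1 and compound 2 cannot be ranked against each other.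

Compound 4 `COc1ccccc1N1CCN(CC(=O)Nc2nc3ccccc3[nH]2)CC1` is not yet measured. Its difference from compound 3 is 2-methoxyphenyl in place of 4-nitrophenyl on an amine nitrogen in a ring.

The step that bears on this change is a number 22.4 percentage points higher from compound 1 to compound 3 (beyond the scatter), in which nitro on an aromatic carbon entered and the number rose by a modest amount. Going to compound 4 takes that nitro away again and puts a methoxy group on the phenyl ring instead; no measured step shows what a methoxy group on this phenyl ring does. Without the nitro, the number is expected to fall back toward the level of compound 1, so a downward step a number 17.9 percentage points lower from compound 3 to compound 4 (beyond the scatter) beyond the scatter is expected. For compound 4 the expected value in this assay is 16%, with a range from 6% to 28%.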

Compound 4, a percentage reported as activity, at one concentration (the size of the read-out at that concentration, not a potency): 21.3%
Compound 4: the middle estimate sits 5.3 percentage points below what was measured; the measured number falls inside the stated range.
By their numbers in this assay, from the lowest: compounds 1, 2 and 4 (each within the scatter of the next); then compound 3.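

In this assay, the step of a number 12.6 percentage points lower from compound 3 to compound 4 (beyond the scatter) shows that a group on the phenyl ring does not by itself keep the higher number: 2-methoxyphenyl on this ring nitrogen does not match 4-nitrophenyl. The steps of a number 9.8 percentage points higher from compound 1 to compound 4 (within the scatter) and a number 0.9 percentage points higher from compound 2 to compound 4 (within the scatter) show that 2-methoxyphenyl cannot be told apart from plain phenyl or from pyrimidin-2-yl, so among the four groups at this place, only 4-nitrophenyl stands clear of the others. No measurement here accounts for this difference.

As far as these compounds go, the two substituted phenyl groups differ both in the group they carry and in where it sits on the ring, so it remains open which of these matters; 2-nitrophenyl and 4-methoxyphenyl would separate the two. Also open, from the compounds shown here alone, is whether other groups on the phenyl ring, such as 4-aminophenyl or 4-carboxyphenyl, would reach the number of compound 3 or stay with the other three compounds.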